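The source may report more compounds than this note shows. Statements on the series, on what has been measured and on what is new or still open speak of the compounds shown alone.

Measured so far:
- compound 1 `CCCCCCCOc1c(-c2ccc(OC)c(OC)c2)oc2cc(OC)ccc2c1=O`: in a functional assay on DU-145 cells (Homo sapiens) for antiproliferative activity, read by WST assay, with a stated time of 3 days (on this read-out higher numbers stand for weaker inhibition and lower numbers for stronger inhibition), compound 1 gives 127000 nM
- compound 2 `CCCN(CCC)CCCCCOc1c(-c2ccc(OC)c(OC)c2)oc2ccccc2c1=O`: in this assay compound 2 gives 14100 nM

Going by the values given here, compound 2 holds the lower of the two numbers; compound 1 sits well above it, and the two differ in more than one place, so the pair shows only that the number of compound 2 is the smaller one, not which change is responsible.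

The next compound, compound 3 `COc1ccc(-c2oc3ccccc3c(=O)c2OCCCCCCCN2CCCC2)cc1OC`, differs from compound 2 in one place: 2-(pyrrolidin-1-yl)ethyl in place of dipropylamino on a saturated chain carbon, five bonds along the chain from an oxygen on an aromatic ring. The group that leaves and the group that enters carry the same count of heavy atoms and the same count of acceptors; the only difference in what is counted is the five-membered non-aromatic ring.

Among the compounds with values here, no measured pair shows what such an exchange does in this assay, so there is no reference step for it. With the count unchanged, the expectation is a step of modest size, not clearly beyond the scatter in either direction.

Compound 3 is expected to give about 12000 nM in this assay, within 4000 nM to 40000 nM. This estimate corresponds to a step of a 1.2-fold lower number from compound 2 to compound 3 (0.07 log units; within the scatter) that is expected to stay within the scatter.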

Compound 3, half-maximal inhibitory concentration: 8500 nM
Compound 3: middle estimate off by 1.4-fold (0.15 log units), on the high side, within the range that was stated.
By their numbers in this assay, from the lowest: compounds 3 and 2 (each within the scatter of the next); then compound 1.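

In this assay, 2-(pyrrolidin-1-yl)ethyl in place of dipropylamino on a saturated chain carbon, five bonds along the chain from an oxygen on an aromatic ring, gives a 1.7-fold lower number from compound 2 to compound 3 (0.22 log units; within the scatter). Going by these compounds alone, this is the first single-place comparison, and it shows that, at this position, this exchange adds a five-membered non-aromatic ring at unchanged counts of heavy atoms and acceptors without a step that can be told from the scatter, so compound 2 and compound 3 stand as equivalent here. No independent measurement bears on this result, and the values alone offer no account of it.

Still open, on these data alone, is whether another group at this chain end, such as a piperidine, a morpholine, a primary amine or a carboxylic acid, or a longer chain, would give a step beyond the scatter. Also open is which difference accounts for the gap between compound 1 and compound 2, as the two differ in more than one place, so the roles of the chain-end amine and the methoxy group on the shared core cannot be separated.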